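Amide nitrogen substituent: the step to compound 4

This account rests on a few compounds, and the source may have more. Where it says the series, first, only, none or still open, it means among the compounds named here.

Values in a functional assay on Huh-7 cells (Homo sapiens) for inhibition, read by MTT assay, with a stated time of 48 h; on this read-out lower numbers stand for stronger inhibition and higher numbers for weaker inhibition:
Compound 1 `COc1ccc2c(=O)c(/C=C/C(=O)Nc3cccc(Cl)c3)coc2c1` gives > 100000 nM, which is a limit of the assay.
Compound 2 `COc1ccc2c(=O)c(/C=C/C(=O)Nc3ccc(C)cc3)coc2c1` gives > 100000 nM, also a limit of the assay.
Compound 3 `CCOc1ccc(NC(=O)/C=C/c2coc3cc(OC)ccc3c2=O)cc1` gives 3230 nM.

For the measured compounds named here, compound 3 holds the only number among the three; the other two values are limits (the limit of > 100000 nM in this assay, at which 2 of the 3 values shown sit). Its step from compound 1 is an at least 30-fold lower number from compound 1 to compound 3 (1.49 log units; beyond the scatter) and its step from compound 2 is an at least 30-fold lower number from compound 2 to compound 3 (1.49 log units; beyond the scatter), while the step that the two limits leave unreadable from compound 1 to compound 2 cannot be read. Compound 4 `COc1ccc2c(=O)c(/C=C/C(=O)NCc3ccccc3F)coc2c1` differs from compound 3 by 2-fluorobenzyl in place of 4-ethoxyphenyl on an amide-type nitrogen. Going by the values given here, the two readable steps both concern the group on the amide-type nitrogen and both are large; they show 4-ethoxyphenyl as the only group at this place that has returned a number in this assay. Among the compounds with values here, no measured compound carries a benzyl group on that nitrogen, so the step to compound 4 has no direct precedent. A loss is expected because two of the three values sit at the limit (the limit of > 100000 nM in this assay, at which 2 of the 3 values shown sit) and compound 3 is the lone exception. The step from compound 3 to compound 4 is estimated at a 9.3-fold higher number from compound 3 to compound 4 (0.97 log units; beyond the scatter). Compound 4 is expected to give about 30000 nM, within 5000 nM to 150000 nM, with a real chance that only a limit is reported.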

Compound 4, half-maximal inhibitory concentration: 8450 nM
Estimate against measurement, compound 4: 3.6-fold (0.55 log units) above; the range from low to high includes it.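

In this assay, for the compounds shown here, 4-ethoxyphenyl is no longer the only group on the amide-type nitrogen that returns a number: 2-fluorobenzyl does so too, and replacing one with the other costs only a modest step, a 2.6-fold higher number from compound 3 to compound 4 (0.42 log units; beyond the scatter). The position therefore tolerates a benzyl group as well as a substituted phenyl group, and the 2-fluorobenzyl group stands clear of the 4-methylphenyl and 3-chlorophenyl groups, with an at least 11-fold lower number from compound 2 to compound 4 (1.07 log units; beyond the scatter) and an at least 11-fold lower number from compound 1 to compound 4 (1.07 log units; beyond the scatter). Both of these steps start from a limit, so they give only a minimum size, and compounds 1 and 2 still give no number to set against compound 4: the limit of > 100000 nM in this assay, at which 2 of the 4 values shown sit.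

A single benzyl compound cannot separate the contribution of the fluorine from that of the benzyl group, and plain benzyl or 4-ethoxybenzyl on the same nitrogen would be needed to tell the two apart. Going by these compounds, it also remains open whether a longer chain such as phenethyl, or a chain ending in an amine or a carboxylic acid, would keep a number in this read-out or fall back to the limit.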